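The source may hold more compounds than are shown below. What is called first, only, known or untested is meant among the compounds shown, and "the series" means these compounds.

Measured in a functional assay (trachea) with Cavia porcellus as the target; a higher number here means a weaker inhibitor, a lower number a stronger inhibitor:
- compound 1 `Cn1nc(-c2cccnc2)c2ccccc2c1=O`: 11500 nM
- compound 2 `CCn1nc(-c2cccnc2)c2ccccc2c1=O`: 1320 nM
- compound 3 `CCCn1nc(-c2cccnc2)c2ccccc2c1=O`: 3160 nM

Compound 3 holds the second highest of these three numbers, lying above compound 2 and below compound 1. Compound 4 `CC(C)n1nc(-c2cccnc2)c2ccccc2c1=O` has the same atoms joined differently: isopropyl in place of propyl on an aromatic nitrogen, with isopropyl in place of propyl on an aromatic nitrogen. Within the data shown here, three measured steps bear on this change, all modest: an 8.7-fold lower number from compound 1 to compound 2 (0.94 log units; beyond the scatter), a 3.6-fold lower number from compound 1 to compound 3 (0.56 log units; beyond the scatter) and a 2.4-fold higher number from compound 2 to compound 3 (0.38 log units; beyond the scatter). None of them tests a branched group, so they guide the size of the step only loosely. In this assay, no step beyond the scatter is expected, with a slight lean towards compound 2 at 1320 nM. The estimated change is a 1.3-fold lower number from compound 3 to compound 4 (0.10 log units; within the scatter). Compound 4 is estimated at 2500 nM, with an expected range of 900 nM to 7000 nM.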

Compound 4, half-maximal inhibitory concentration: 3090 nM
Beside the measured number, compound 4's estimate is 1.2-fold (0.09 log units) below it, and the stated range covers the measured number.
By their numbers in this assay, from the lowest: compound 2; then compounds 4 and 3 (each within the scatter of the next); then compound 1.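

Propyl and isopropyl on the aromatic nitrogen cannot be told apart in this assay (a 1.0-fold lower number from compound 3 to compound 4 (0.01 log units; within the scatter)), so at this position the branched chain reads the same as the straight one. Isopropyl also falls short of ethyl (a 2.3-fold higher number from compound 2 to compound 4 (0.37 log units; beyond the scatter)) yet stays better than methyl (a 3.7-fold lower number from compound 1 to compound 4 (0.57 log units; beyond the scatter)), just as propyl does. No measured evidence accounts for these results. The compounds shown leave open how a longer chain such as butyl, a cyclopropyl group or an amine on the chain would read at this position.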